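Swapping an aryl group for furan in a series at the limit

The source may report more compounds than this note shows. Statements on the series, on what has been measured and on what is new or still open speak of the compounds shown alone.

Compound 1 `CC(=O)c1nn(-c2ccc(Cl)cc2)/c(=N/c2nc(-c3c(C)n(C)n(-c4ccccc4)c3=O)cs2)s1` gives > 100000 nM in a functional assay on MCF7 cells (Homo sapiens) for cytotoxicity, read by sulforhodamine B assay, with a stated time of 72 h (on this read-out higher numbers stand for weaker inhibition and lower numbers for stronger inhibition), which is a limit of the assay and not a number.
Compound 2 `Cc1c(-c2csc(/N=C3\S/C(=C\c4ccccc4)C(=O)N3c3ccccc3)n2)c(=O)n(-c2ccccc2)n1C` gives > 100000 nM in this assay, again a limit.
Compound 3 `Cc1c(-c2csc(/N=C3\S/C(=C\c4ccc(N(C)C)cc4)C(=O)N3c3ccccc3)n2)c(=O)n(-c2ccccc2)n1C` gives > 100000 nM in this assay, again a limit.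

Every measured value sits at the same ceiling of this assay (the limit of > 100000 nM in this assay, at which 3 of the 3 values shown sit), so none of the three compounds has a numbered result. Compound 3 therefore stands at that limit, with no numbered value of its own. The step from compound 2 to compound 3 is a step that the two limits leave unreadable from compound 2 to compound 3; the two limits hide its size and its direction.

Compound 4 `Cc1c(-c2csc(/N=C3\S/C(=C\c4ccco4)C(=O)N3c3ccccc3)n2)c(=O)n(-c2ccccc2)n1C` differs from compound 3 by furan-2-yl in place of 4-(dimethylamino)phenyl on a double-bonded chain carbon bound to a double-bonded ring carbon. Within the data shown here, the only measured step at this position is the one from compound 2 to compound 3, and it cannot be read, so no measured step supplies a size or a direction for the new change. Three compounds at the limit give no ground to expect a readable result. Compound 4 is therefore expected to give 200000 nM, within 50000 nM to 1000000 nM, and most probably to be reported only as a limit. The step is expected to be a step that the limit leaves unreadable from compound 3 to compound 4, meaning no change that could be read.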

Compound 4, half-maximal inhibitory concentration: 22400 nM
The estimate for compound 4 lay 8.9-fold (0.95 log units) above the measured number; the measured number lies below the stated range.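

In this assay, the group on the double-bonded chain carbon bound to a double-bonded ring carbon can change the read-out: furan-2-yl in place of 4-(dimethylamino)phenyl gives an at least 4.4-fold lower number from compound 3 to compound 4 (0.64 log units; beyond the scatter), and furan-2-yl in place of phenyl gives an at least 4.4-fold lower number from compound 2 to compound 4 (0.64 log units; beyond the scatter). Both steps lie beyond the usual scatter, and each is only a minimum, so the true drop could be larger than printed. The step between the two aryl compounds, compound 2 and compound 3, cannot be read, so only the entry of furan-2-yl reveals that this position can register a change at all, while the remaining values stay at the ceiling: the limit of > 100000 nM in this assay, at which 3 of the 4 values shown sit.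

The compounds shown leave open whether this drop belongs to furan-2-yl in particular or would also appear with another small aromatic ring here, such as thiophen-2-yl or pyridin-2-yl, or with a furan-2-yl ring carrying a methyl or a carboxylic acid. Among these compounds, compound 4 gives 22400 nM, the only real number in the set, so no trend between numbered compounds can yet be drawn.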